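Aryl Swap on the Triazole of a Spiro Series

The source may hold more compounds than are shown below. What is called first, only, known or untested is meant among the compounds shown, and "the series" means these compounds.

The measured compounds:
compound 1, `N#CC1=C(N)Oc2c(c3nc4ccccc4nc3c3ccccc23)C12C(=O)N(Cc1cnnn1-c1cccc(Cl)c1)c1ccccc12`, gives 43600 nM
compound 2, `Cc1ccc(-n2nncc2CN2C(=O)C3(C(C#N)=C(N)Oc4c3c3nc5ccccc5nc3c3ccccc43)c3ccccc32)cc1Cl`, gives > 50000 nM, a limit of the assay
compound 3, `N#CC1=C(N)Oc2c(N)cc3nc4ccccc4nc3c2C12C(=O)N(Cc1cnnn1-c1ccccc1Br)c1ccccc12`, gives 30700 nM

These three share one core and differ in the aryl group carried on the triazole. In a functional assay on MCF7 cells (Homo sapiens) for antiproliferative activity, read by MTT assay, with a stated time of 48 h (a higher number here means a weaker inhibitor, a lower number a stronger inhibitor), compound 1 gives 43600 nM. Compound 2 reaches only the limit of > 50000 nM in this assay, so no number is known for it; (the limit of > 50000 nM in this assay, at which 1 of the 3 values shown sits). Compound 3, measured in this assay at 30700 nM, sits within the scatter of compound 1, so the two cannot be ordered.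

Compound 4, `COc1ccc(OC)c(-n2nncc2CN2C(=O)C3(C(C#N)=C(N)Oc4c(N)cc5nc6ccccc6nc5c43)c3ccccc32)c1`, has not yet been measured. It differs from compound 3 by 2,5-dimethoxyphenyl in place of 2-bromophenyl on an aromatic nitrogen. Within the data shown here, the only measured step, an at least 1.1-fold higher number from compound 1 to compound 2 (0.05 log units; that floor lies within the scatter), also alters the aryl group on the triazole, but it exchanges methyl for hydrogen on an aromatic carbon and reaches a limit, so it gives no number for the change at hand. Nothing measured here speaks for a shift beyond the scatter in either direction, and compound 4 is expected to stay near compound 3: the expected step is a 1.1-fold higher number from compound 3 to compound 4 (0.03 log units; within the scatter). For compound 4 the estimate in this assay is 33000 nM, expected to lie between 12000 nM and 50000 nM.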

Compound 4, half-maximal inhibitory concentration: 28100 nM
Beside the measured number, compound 4's estimate is 1.2-fold (0.07 log units) above it; the range from low to high includes it.
By their numbers in this assay, from the lowest: compounds 4, 3 and 1 (each within the scatter of the next). At a limit, above all of these: compound 2.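

In this assay, among these compounds, the change on the triazole from 2-bromophenyl to 2,5-dimethoxyphenyl gives a 1.1-fold lower number from compound 3 to compound 4 (0.04 log units; within the scatter) and is the first aryl change at this position with a number at both ends, since the earlier step ended at a limit. It shows that this aromatic nitrogen of the triazole can carry a group of 10 heavy atoms with 2 hydrogen-bond acceptors in place of one of 7 heavy atoms with none, and that the read-out stays within the scatter even though the bromine is lost and two methoxy groups enter. No measurement given here accounts for the two aryl groups reading alike.

As far as these compounds go, what stays open is whether any group on this nitrogen can move the read-out beyond the scatter, as the two aryl groups compared here leave the number where it was. A phenyl ring bearing an amine or a carboxylic acid, or a longer alkyl chain in place of the aryl ring, would test that on the shared core.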